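Carboxyphenoxy variant on the shared core

A few compounds are considered here, and "the series" means these few. Any claim that something is new, unique, unknown or untested is made for them only; others in the source may bear on it.

Compound 3 `Cc1ccccc1-n1nc(C)c2c1NC(=O)[C@H](C)S[C@@H]2c1ccc(-c2ccsc2)cc1` was tested in an assay on isolated protein for agonist activity at Bile acid receptor (Homo sapiens), read by AlphaScreen, with a stated time of 30 min (a higher number here means that more compound is needed for the effect, a lower number that less compound is needed), where compound 3 gives 1400 nM. Compound 1 `CCc1ccccc1-n1nc(C)c2c1NC(=O)[C@H](C)S[C@@H]2c1ccc(Oc2ccccc2)cc1` gives 1100 nM and compound 2 `COc1cccc(-c2ccc([C@H]3S[C@@H](C)C(=O)Nc4c3c(C)nn4-c3ccccc3C)cc2)c1` gives 1800 nM; all three numbers lie within the scatter of one another, so compound 3 cannot be set apart from either neighbour. Within the data shown here, the one single-site step among the measured compounds, a 1.3-fold lower number from compound 2 to compound 3 (0.11 log units; within the scatter), is within the scatter.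

Compound 4 `Cc1ccccc1-n1nc(C)c2c1NC(=O)[C@H](C)S[C@@H]2c1ccc(Oc2cccc(C(=O)O)c2)cc1` differs from compound 3 at one place: 3-carboxyphenoxy in place of thiophen-3-yl on an aromatic carbon. Among the measured compounds shown here, no measured step covers this exact exchange. For the measured compounds named here, compound 1 carries phenoxy where compound 3 carries thiophen-3-yl, but compound 1 also bears ethyl on the shared core, so its value shows only that a phenoxy-type group sits within the scatter of compound 3. The carboxyl adds a hydrogen-bond donor absent from every measured compound; the data are silent on it. On the measured aryl exchange, which moved little, the step expected from compound 3 to compound 4 is a 1.3-fold lower number from compound 3 to compound 4 (0.10 log units; within the scatter), none beyond the scatter. The estimate for compound 4 in this assay is 1100 nM, with a range from 300 nM to 4000 nM.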

Compound 4, half-maximal effective concentration: "not active" (no number reported)
No number was reported for compound 4, and the estimate cannot be compared.
By their numbers in this assay, from the lowest: compounds 1, 3 and 2 (each within the scatter of the next).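

Among these compounds, compound 4 is reported as "not active" without a number in this assay, so no step from compound 3 to compound 4 can be read. Nothing shown bears on this result.

The compounds shown leave open whether the 3-carboxyphenoxy group as a whole or its carboxyl alone accounts for the result.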